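The compounds below may be only part of what the source reports. "The series", "measured", "known", "first", "only" and "open" are said of these compounds alone.

Three compounds have been measured in an ADME assay on Vero cells (Chlorocebus sabaeus) for cytotoxicity, read by MTT assay, with a stated time of 72 h; a higher number here means a weaker inhibitor, a lower number a stronger inhibitor:

compound 1, `COc1c(N2CCN(C(=O)C3COc4ccccc4O3)CC2)c(F)cc2c(=O)c(C(=O)O)cn(C3CC3)c12`, gives 119000 nM
compound 2, `COc1c(N2CC(C)OC(C)C2)c(F)cc2c(=O)c(C(=O)O)cn(C3CC3)c12`, gives 160000 nM
compound 3, `COc1c(N2CCN(C(=O)C3COc4ccccc4O3)CC2)c(F)c([N+](=O)[O-])c2c(=O)c(C(=O)O)cn(C3CC3)c12`, gives 110000 nM

Compound 1 and compound 3 share one core and differ in a single place: nitro in place of hydrogen on an aromatic carbon. This change gave a 1.1-fold lower number from compound 1 to compound 3 (0.03 log units; within the scatter), so the two numbers are indistinguishable within the usual scatter. Compound 2 rests on a different core, and the difference between the two cores is not broken down here; its value and those of compound 1 and compound 3 all lie within the scatter of one another.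

Compound 4, `COc1c(N2CC(C)OC(C)C2)c(F)c([N+](=O)[O-])c2c(=O)c(C(=O)O)cn(C3CC3)c12`, is not yet measured. It differs from compound 2 by the same kind of change: nitro in place of hydrogen on an aromatic carbon. The surroundings of the place differ slightly in wording, as the new group in compound 4 sits meta to a 2,6-dimethylmorpholin-4-yl group, whereas in compound 3 it sits meta to a large group.

Because the earlier step of a 1.1-fold lower number from compound 1 to compound 3 (0.03 log units; within the scatter) stayed within the scatter, the step from compound 2 to compound 4 is expected to be similarly small, a 1.1-fold lower number from compound 2 to compound 4 (0.03 log units; within the scatter). Compound 4 is therefore estimated at 150000 nM in this assay, likely between 90000 nM and 250000 nM.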

Compound 4, half-maximal inhibitory concentration: 144000 nM
Estimate against measurement, compound 4: 1.0-fold (0.02 log units) above; measured number inside the range.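

In this assay, nitro in place of hydrogen on an aromatic carbon gives a 1.1-fold lower number from compound 2 to compound 4 (0.05 log units; within the scatter), so compound 2 and compound 4 cannot be told apart in this read-out. Set beside the same change on the other core, the new step agrees with the earlier one: the same change on two cores in this assay, a 1.1-fold lower number (0.03 log units; within the scatter) from compound 1 to compound 3 and a 1.1-fold lower number (0.05 log units; within the scatter) from compound 2 to compound 4, 1.0-fold (0.01 log units) apart, within the scatter of two such steps. This shows that, on these two cores, the change leaves the number within the scatter both times, but it does not show that a real effect carries from one core to another, since neither step is large enough to be distinguished from repeat-measurement noise, and two cores cannot speak for the whole series or for any other assay.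

The compounds shown leave open whether a different group on that same aromatic carbon, such as an amine or a longer chain, would move the number beyond the scatter. They also leave open whether nitro would stay as silent on a core carrying something other than a methoxy group.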